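The source may hold more compounds than are shown below. What is called first, only, known or untested is meant among the compounds shown, and "the series" means these compounds.

In a functional assay on MV4-11 cells (Homo sapiens) for inhibition, read by luminescence, with a stated time of 72 h, tested at 5 uM (a lower number here means less inhibition of growth, a higher number more inhibition of growth at the concentration tested), compound 1 (`C=CS(=O)(=O)NC/C=C/c1cc(OC)cc(O)c1C(=O)OC(C)C`) gives 72.3%, compound 2 (`C=CS(=O)(=O)NC/C=C/c1cc(OC)cc(O)c1C(=O)OCc1ccc(Br)cc1`) gives 61% and compound 3 (`C=CS(=O)(=O)NC/C=C/c1cc(OC)cc(O)c1C(=O)OCC(C)c1ccccc1`) gives 9.6%. Compound 3 is the lowest of the three, and both of its steps from the others are beyond the scatter.

Compound 4 (`COc1cc(O)c(C(=O)OCC(C)c2ccccc2)c(/C=C/CN2C(=O)C=CC2=O)c1`) keeps the 2-phenylpropyl group of compound 3 on the oxygen next to a carbonyl group. The change lies elsewhere: a group of 7 heavy atoms (4 carbon, 1 nitrogen, 2 oxygen; one five-membered non-aromatic ring with 1 hetero atom) in place of a group of 6 heavy atoms (2 carbon, 1 nitrogen, 2 oxygen, 1 sulfur; no ring), on a saturated chain carbon bound to a double-bonded chain carbon. Among the measured compounds shown here, the (vinylsulfonyl)amino group leaves, and no measured pair shows what happens when it is replaced.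

The three measured steps all concern the group on the oxygen next to a carbonyl group. They are a number 11.3 percentage points lower from compound 1 to compound 2 (beyond the scatter), a number 62.7 percentage points lower from compound 1 to compound 3 (beyond the scatter) and a number 51.4 percentage points lower from compound 2 to compound 3 (beyond the scatter). They do not measure the present change and show only that a single replacement in this series can produce a modest or a large step in this assay.

Compound 3 at 9.6% leaves far more room upward than downward, so any step beyond the scatter is more likely to be a rise, though its size is poorly constrained. A moderate rise is expected, estimated as a number 12.4 percentage points higher from compound 3 to compound 4 (beyond the scatter). The expected value for compound 4 is 22%, with an estimated range of 2% to 60%.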

Compound 4, percent growth inhibition at one concentration: 99%
Estimate against measurement, compound 4: 77 percentage points below, and the stated range ends below it.
By their numbers in this assay, from the lowest: compound 3; then compound 2; then compound 1; then compound 4.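

Replacing the (vinylsulfonyl)amino group on the saturated chain carbon bound to a double-bonded chain carbon gives a number 89.4 percentage points higher from compound 3 to compound 4 (beyond the scatter) in this assay, so this place can carry a large step, and the series is not governed by the group on the oxygen next to a carbonyl group alone. The low reading of compound 3 is therefore not fixed by its 2-phenylpropyl group, since compound 4 keeps that group and gives 99% at the single concentration tested. Nothing available accounts for the size of this step, and no supporting data bear on it.

The compounds shown do not tell whether the same replacement would give a similar step with the isopropyl group of compound 1 or the 4-bromobenzyl group of compound 2 on that oxygen, and with compound 4 this close to the top of the scale, a single-concentration reading says little about how far its activity extends. They also leave open how a plain amine or an acetamide at the same place would read, which would show how much of the step depends on the entering group with its five-membered non-aromatic ring.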